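This account rests on a few compounds, and the source may have more. Where it says the series, first, only, none or still open, it means among the compounds named here.

Working notes on the series.

Three compounds have numbers in an ADME assay on microsomes from liver (Homo sapiens) for metabolic stability, tested at 2.5 uM (a lower number here means slower removal, a higher number faster removal of the compound), so far. Compound 1 `Fc1ccc2c(c1)nnn2Cc1ccc(-c2ccc(Cl)cc2F)nc1` gives 0.1 mL/min/g in this assay. Compound 2 `Fc1ccc(Cn2nnc3c(Br)cccc32)c(Cl)c1` gives 1.8 mL/min/g. Compound 3 `Brc1cccc2c1nnn2CC1CCCC1` gives 7.9 mL/min/g, which is the highest of the three numbers; its gap to compound 2, the nearest, is beyond the scatter, and its gap to compound 1, the furthest, is far beyond it. Among the measured compounds shown here, none of these three compounds differs from another in only one place, so no single-point step is available among the measured set.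

The next compound, compound 4 `Brc1cccc2c1nnn2CC1CCC1`, has not been measured in this assay. It differs from compound 3 by cyclobutyl in place of cyclopentyl on a saturated chain carbon bound to an aromatic nitrogen. For the measured compounds named here, no measured pair shows this change, so the expectation rests on compound 3 alone: its value of 7.9 mL/min/g is taken as the anchor, and the step from compound 3 to compound 4 is expected to be a 1.4-fold lower number from compound 3 to compound 4 (0.16 log units; within the scatter), a small step, if anything toward a lower number, and within the scatter of repeated measurements. Compound 4 is therefore estimated at 5.5 mL/min/g in this assay, with a range from 2.5 mL/min/g to 12 mL/min/g.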

Compound 4, intrinsic clearance in a liver preparation (reported as CLH), per the amount of preparation that the assay uses: 8.7 mL/min/g
Compound 4: the middle estimate sits 1.6-fold (0.20 log units) below what was measured; low and high end bracket the measured number.
By their numbers in this assay, from the lowest: compound 1; then compound 2; then compounds 3 and 4 (each within the scatter of the next).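

Among the compounds shown here, this is the first pair that differs in one place, and it gives a direct reading in this assay: the step is a 1.1-fold higher number from compound 3 to compound 4 (0.04 log units; within the scatter), so cyclobutyl and cyclopentyl on a saturated chain carbon bound to an aromatic nitrogen cannot be told apart by this read-out. For this pair, with the rest of the structure held constant, the four-membered non-aromatic ring of carbon only and the five-membered one give numbers within the scatter of each other, and the change of ring size alone yields no usable difference at this position. No measured evidence bears on why the two compounds read alike, and the pair alone offers no account of it.

As far as these compounds go, it remains open whether a group of another kind at this place, such as an open-chain butyl group, a piperidine ring carrying an amine or a carboxylic acid, would give a step beyond the scatter. From the compounds shown here alone, it also remains open whether the same exchange of cyclobutyl for cyclopentyl would read alike on a different core, such as that of compound 1.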